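This account rests on a few compounds, and the source may have more. Where it says the series, first, only, none or still open, it means among the compounds named here.

Measured compounds:
compound 1 `CCc1cccc(NC(=O)CN2CCN(c3ccccn3)CC2)c1` — 26.2%
compound 2 `O=C(CN1CCN(c2ccccn2)CC1)Nc1cccnc1` — 19%
compound 3 `Cc1cccc(NC(=O)CN2CCC(c3ccccc3)CC2)c1` — 14%

In an assay on cells for agonist activity at D(4) dopamine receptor (Homo sapiens), read by luminescence and beta-arrestin recruitment, with a stated time of 90 min (on this read-out lower numbers stand for smaller maximal responses and higher numbers for larger maximal responses), compound 1 gives the highest of the three numbers. Compound 2 sits closest, and the change a number 7.2 percentage points lower from compound 1 to compound 2 (within the scatter) is within the scatter, while compound 3, a number that is lower beyond the scatter, lies furthest away.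

Compound 4 `CCc1cccc(NC(=O)CN2CCN(c3ccc(Cl)cn3)CC2)c1` is not yet measured. It differs from compound 1 by chloro in place of hydrogen on an aromatic carbon, a change on the pyridin-2-yl ring. Going by the values given here, none of the measured steps touches that ring; the only measured step alters the amide-side group instead, so no measured comparison speaks to this change. Compound 4 is therefore expected to show no step beyond the scatter, an estimated a number 0.2 percentage points lower from compound 1 to compound 4 (within the scatter). The estimate for compound 4 in this assay is 26%, within 12% to 42%.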

Compound 4, largest response reached (Emax), in percent of the reference or control that the assay uses: "not active" (no number reported)
Compound 4: no number reported; the estimate stays without a comparison.
By their numbers in this assay, from the lowest: compounds 3, 2 and 1 (each within the scatter of the next, the first and the last beyond it).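

Going by these compounds alone, compound 4 is reported as "not active" in this assay without a number, so no step from compound 1 can be read. Nothing available explains this result. The compounds shown leave open how other changes on the pyridin-2-yl ring of compound 1 would read out.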